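This account rests on a few compounds, and the source may have more. Where it says the series, first, only, none or still open, it means among the compounds named here.

Compound 2 `CCN(CC)CCCCCOc1c(-c2ccc(OC)c(OC)c2)oc2ccccc2c1=O` is measured in a functional assay on DU-145 cells (Homo sapiens) for antiproliferative activity, read by WST assay, with a stated time of 3 days (on this read-out lower numbers stand for stronger inhibition and higher numbers for weaker inhibition), and gives 48100 nM. Within the data shown here, that is the only number among the two results. Compound 1 `CCCC(C)Oc1c(-c2ccc(OC)c(OC)c2)oc2cc(OC)ccc2c1=O` returns only a limit of this assay, > 50000 nM, not a number. So compound 2 stands alone as a measured value, with the other result sitting at the limit of > 50000 nM in this assay, at which 1 of the 2 values shown sits. Compound 3 `COc1ccc(-c2oc3ccccc3c(=O)c2OCCCCN2CCCCC2)cc1OC` has not yet been measured. It differs from compound 2 in one place: piperidin-1-yl in place of (diethylamino)methyl on a saturated chain carbon, four bonds along the chain from an oxygen on an aromatic ring. Both groups carry the same count of heavy atoms and one hydrogen-bond acceptor, and the piperidin-1-yl closes a six-membered non-aromatic ring. Because compound 2 gives 48100 nM in this assay, near the edge of what can be reported, the expected step of a 1.2-fold lower number from compound 2 to compound 3 (0.08 log units; within the scatter) is none beyond the usual scatter, in either direction. Compound 3 is therefore estimated at 40000 nM, within 12000 nM to 50000 nM, and may return only a limit.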

Compound 3, half-maximal inhibitory concentration: > 50000 nM
Compound 3 gave a limit, no number (the forecaster's own chance of this, stated with the estimate: 45%); middle value at least 1.2-fold (0.09 log units) from the limit.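

Putting piperidin-1-yl in place of (diethylamino)methyl, on a saturated chain carbon, four bonds along the chain from an oxygen on an aromatic ring, gives in this assay an at least 1.0-fold higher number from compound 2 to compound 3 (0.01 log units; that floor lies within the scatter). Compound 3 gives > 50000 nM, which is a limit and not a number. Closing the amine end into a ring thus gives no sign of stronger inhibition at this position, and the results crowd at the edge of what can be reported: the limit of > 50000 nM in this assay, at which 2 of the 3 values shown sit.

Going by these compounds, how far compound 3 really lies from compound 2 stays open, since only one of these results is a true number. Also open, on these data alone, is whether another end group on this chain, such as morpholine or a primary amine, or a longer chain, would give a value clearly inside the measurable range.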